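The source may hold more compounds than are shown below. What is called first, only, known or untested is meant among the compounds shown, and "the series" means these compounds.

Measured in an ADME assay on BaF3 cells (Mus musculus) for cytotoxicity, read by MTT assay, with a stated time of 48 h; on this read-out higher numbers stand for weaker inhibition of growth and lower numbers for stronger inhibition of growth:
- compound 1 `CC(C)n1nc(-c2cc(C3CCCCC3)on2)c2c(N)ncnc21`: > 10000 nM (a limit)
- compound 2 `Nc1ncnc2c1c(-c1cc(C3CC3)on1)nn2C1CCCCC1`: > 10000 nM (a limit)
- compound 3 `CC(C)n1nc(-c2cc(-c3ccccc3)on2)c2c(N)ncnc21`: > 10000 nM (a limit)

For the measured compounds named here, no compound in this set has yet given a number. The whole set sits at one reading: the limit of > 10000 nM in this assay, at which 3 of the 3 values shown sit. Compound 2, the starting point for this step, gives only a limit, > 10000 nM, and not a number.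

Compound 4 `Nc1ncnc2c1c(-c1cc(C3CC3)on1)nn2C1CCOCC1` carries oxan-4-yl in place of cyclohexyl on an aromatic nitrogen, the position next to the ring nitrogen of the shared core: oxan-4-yl in place of cyclohexyl on an aromatic nitrogen.

Going by the values given here, the one measured step is a step that the two limits leave unreadable from compound 1 to compound 3. It places phenyl in place of cyclohexyl on an aromatic carbon, which is a different place from the one changed here, and it has no readable size to carry over. Among the compounds with values here, no measured step therefore tests the change on the aromatic nitrogen, and the expectation rests on the limit of compound 2 alone.

In this assay the expected change is a step that the limit leaves unreadable from compound 2 to compound 4, and no step beyond the scatter is expected. A further report as a limit is the likelier outcome. Compound 4 is estimated at 12000 nM, with an expected range of 5000 nM to 30000 nM.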

Compound 4, concentration for 50% growth inhibition: > 10000 nM
Compound 4: only a limit was reported; the forecaster's own chance of this, stated with the estimate: 85%; the middle value is on the limit's open side.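

Compound 2 and compound 4 both give only limits, so no step between them can be read, and the set stays at one reading: the limit of > 10000 nM in this assay, at which 4 of the 4 values shown sit.

The compounds shown leave open whether oxan-4-yl in place of cyclohexyl changes growth inhibition at all in this assay, and how large any such change would be.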